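The compounds below may be only part of what the source reports. "The series", "measured", "known", "first", "only" and "open" are said of these compounds alone.

In a functional assay on HepG2 cells (Homo sapiens) for antiproliferative activity, read by MTT assay, with a stated time of 48 h (on this read-out higher numbers stand for weaker inhibition and lower numbers for stronger inhibition), three compounds that share one core have been measured. Compound 1 `CCN1C(=O)C(=O)c2cc(-c3ccc(OC)cc3)ccc21` gives 4470 nM. Compound 2 `COc1ccc(-c2ccc3c(c2)C(=O)C(=O)N3Cc2ccc(Br)cc2)cc1` gives 700 nM, and compound 3 `COc1ccc(CN2C(=O)C(=O)c3cc(-c4ccc(OC)cc4)ccc32)cc1` gives 50 nM, the lowest of the three numbers. All three measured steps concern the group carried on the saturated chain carbon bound to the amide-type nitrogen in the ring: a 6.4-fold lower number from compound 1 to compound 2 (0.81 log units; beyond the scatter), an 89-fold lower number from compound 1 to compound 3 (1.95 log units; beyond the scatter) and a 14-fold lower number from compound 2 to compound 3 (1.15 log units; beyond the scatter). Compound 4 `COc1ccc(CN2C(=O)C(=O)c3cc(-c4cc(OC)cc(OC)c4)ccc32)cc1` keeps that end of compound 3 unchanged and differs at the other end: 3,5-dimethoxyphenyl in place of 4-methoxyphenyl on an aromatic carbon. Within the data shown here, no measured step touches this part of the core, so the data give no direct guide to how a change there moves the number; the three steps bear only on the group at the nitrogen. Compound 4 is therefore expected to stay close to its predecessor, the expected step being a 1.6-fold higher number from compound 3 to compound 4 (0.20 log units; within the scatter), not beyond the scatter. The estimate for compound 4 in this assay is 80 nM, within a range from 25 nM to 300 nM.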

Compound 4, half-maximal inhibitory concentration: 1200 nM
Compound 4: the middle estimate sits 15-fold (1.18 log units) below what was measured; the measured number lies above the stated range.
By their numbers in this assay, from the lowest: compound 3; then compounds 2 and 4 (each within the scatter of the next); then compound 1.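

In this assay, 3,5-dimethoxyphenyl in place of 4-methoxyphenyl gives a 24-fold higher number from compound 3 to compound 4 (1.38 log units; beyond the scatter), a large step beyond the scatter. The earlier steps shown here changed only the group at the nitrogen, whereas this one shows that the aromatic group at the other end of the shared core can also move the number strongly, here toward weaker inhibition. Nothing measured here shows why this change has such an effect.

The compounds shown leave open whether the step depends on losing 4-methoxyphenyl or on adding 3,5-dimethoxyphenyl, a question that a plain phenyl or a 4-hydroxyphenyl at this place could help to settle. Also open, going by these compounds, is whether the same swap has a similar effect with the 4-bromophenyl of compound 2 at the nitrogen end.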